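The source may hold more compounds than are shown below. What is called first, only, known or untested is meant among the compounds shown, and "the series" means these compounds.

Compound 1 `CCN(CC)c1ccc2cc(C(=O)c3ccc(N4CCN(C(=O)CN5CCNCC5)CC4)cc3)oc2c1` carries an unsubstituted amine nitrogen in a ring; in a functional assay on MCF7 cells (Homo sapiens) for cytotoxicity, read by MTT assay, with a stated time of 48 h (on this read-out higher numbers stand for weaker inhibition and lower numbers for stronger inhibition), compound 1 gives 5340 nM. Compound 2 `CCN(CC)c1ccc2cc(C(=O)c3ccc(N4CCN(C(=O)CN5CCN(C(=O)CCl)CC5)CC4)cc3)oc2c1` places a (chloromethyl)carbonyl on that ring amine nitrogen, and compound 3 `C#CCN1CCN(CC(=O)N2CCN(c3ccc(C(=O)c4cc5ccc(N(CC)CC)cc5o4)cc3)CC2)CC1` a propargyl. In this assay compound 2 reaches only the limit of the assay, > 40000 nM. In this assay compound 3 likewise stops at the assay limit, > 40000 nM, so compound 3 stands at the weak end of the numbers seen. The step of an at least 7.4-fold higher number from compound 1 to compound 2 (0.87 log units; beyond the scatter) and the step of an at least 7.4-fold higher number from compound 1 to compound 3 (0.87 log units; beyond the scatter) point the same way, while the step that the two limits leave unreadable from compound 2 to compound 3 cannot be read from two limits. Compound 4 `CCN(CC)c1ccc2cc(C(=O)c3ccc(N4CCN(C(=O)CN5CCN(Cc6ccc(C#N)cc6)CC5)CC4)cc3)oc2c1` differs from compound 3 by 4-cyanophenyl in place of ethynyl on a saturated chain carbon bound to an amine nitrogen in a ring. Since both substituted ring amines sit at the limit of > 40000 nM in this assay, at which 2 of the 3 values shown sit, a number no better than the limit is expected for compound 4, a number no higher from compound 3 to compound 4 (the limit leaves the size open). Compound 4 is therefore estimated at 40000 nM, between 8000 nM and 200000 nM.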

Compound 4, half-maximal inhibitory concentration: > 40000 nM
Compound 4 gave a limit, no number; the forecaster's own chance of this, stated with the estimate: 60%; the middle value sits exactly at the limit.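

A third, quite different group on the ring amine nitrogen behaves like the first two: in this assay 4-cyanobenzyl gives an at least 7.4-fold higher number from compound 1 to compound 4 (0.87 log units; beyond the scatter), so the loss does not depend on one particular group. For the compounds shown here, compound 1, with its free ring amine, remains the only compound here with a real number, while the others stop at a limit: the limit of > 40000 nM in this assay, at which 3 of the 4 values shown sit. The steps among compound 2, compound 3 and compound 4 cannot be read, since limits are not numbers. On these data alone, whether a methyl or an acetyl on that nitrogen would still give a measurable value remains open.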